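Trading a Saturated Chain End for an Alkene

The source may hold more compounds than are shown below. What is called first, only, known or untested is meant among the compounds shown, and "the series" means these compounds.

Measured compounds:
Compound 1, `CC(/C=C/CC(C)CCCC(C)(C)C)=C\C(=O)OC(C)C`, 7.56
Compound 2, `CC(C)=CCCC(C)C/C=C/C(C)=C/C(=O)OC(C)C`, 6.6
Compound 3, `CCNC(=O)/C=C(C)/C=C/CC(C)CCCC(C)(C)C`, 5.65

The three compounds were measured in a physicochemical assay for lipophilicity; on this read-out lower numbers stand for lower lipophilicity and higher numbers for higher lipophilicity. Compound 1 differs from compound 2 by 2-methylprop-1-en-1-yl in place of neopentyl on a saturated chain carbon, four bonds along the chain from a double-bonded chain carbon, and that change gave a number 0.96 log units lower from compound 1 to compound 2 (beyond the scatter). Compound 1 differs from compound 3 by ethylamino in place of isopropoxy on a carbonyl carbon, a change that gave a number 1.91 log units lower from compound 1 to compound 3 (beyond the scatter), leaving compound 3 with the lowest of the three numbers.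

Compound 4, `CCNC(=O)/C=C(C)/C=C/CC(C)CCC=C(C)C`, has not yet been measured in this assay. Within the data shown here, it stands to compound 3 as compound 2 stands to compound 1: the difference is 2-methylprop-1-en-1-yl in place of neopentyl on a saturated chain carbon, four bonds along the chain from a double-bonded chain carbon, the same change as the one from compound 1 to compound 2, at the same place on the chain. The two cores differ as described above for compound 1 and compound 3.

Since the same change is made on a core that already carries the ethylamino group, the step from compound 3 to compound 4 is expected to be a number 0.96 log units lower from compound 3 to compound 4 (beyond the scatter), resting on the earlier step of a number 0.96 log units lower from compound 1 to compound 2 (beyond the scatter). Compound 4 is therefore estimated at 4.69, with a range from 4.3 to 5.1.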

Compound 4, partition coefficient: 4.69
Beside the measured number, compound 4's estimate shows no gap at the digits printed; the measured number falls inside the stated range.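

In this assay, putting 2-methylprop-1-en-1-yl in place of neopentyl on the core that carries ethylamino gave a step (a number 0.96 log units lower from compound 3 to compound 4 (beyond the scatter)) of the same size as the one on the core of compound 1 (a number 0.96 log units lower from compound 1 to compound 2 (beyond the scatter)). Read the other way, ethylamino in place of isopropoxy gave a step (a number 1.91 log units lower from compound 2 to compound 4 (beyond the scatter)) matching the one with neopentyl in place (a number 1.91 log units lower from compound 1 to compound 3 (beyond the scatter)), so in these four compounds the two changes simply add. Among these compounds, this holds for only two cores and one read-out, so it does not show that the change would carry to any other core, and nothing available explains the match.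

The change removes a carbon and adds a double bond together, and the compounds shown leave these two apart unresolved; an isobutyl group on the same saturated chain carbon would separate them. Going by these compounds, it also remains open whether the same step would hold with an amine or a carboxylic acid in place of ethylamino on the carbonyl carbon.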